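Removing the Side Chain from a Kinase Scaffold

This account rests on a few compounds, and the source may have more. Where it says the series, first, only, none or still open, it means among the compounds named here.

Measured so far:
Compound 1 `COCCNc1nc(C)cc2c1c(N)nn2C` gives -10% in an assay on isolated protein for inhibition of protein kinase C zeta type (Homo sapiens), read by mobility shift assay, tested at 30 uM; a higher number here means more inhibition at the concentration tested (going by the name of the read-out), a lower number less inhibition
Compound 2 `COCCNc1nc(-c2ccccc2)cc2c1c(N)nn2C` gives 20% in this assay

Of the compounds shown here, two have been tested in this assay. For the measured compounds named here, compound 2 stands highest of the two numbers; the nearest is compound 1, and the single known step, a number 30 percentage points higher from compound 1 to compound 2 (beyond the scatter), lies beyond the scatter and is modest in size.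

Compound 3 `Cn1nc(N)c2cnc(-c3ccccc3)cc21` is the next candidate. Its change from compound 2 is hydrogen in place of (2-methoxyethyl)amino on an aromatic carbon. Going by the values given here, no measured step bears on this kind of change: the only step known, a number 30 percentage points higher from compound 1 to compound 2 (beyond the scatter), concerns a different group at a different place, so it gives no guide to what removing the (2-methoxyethyl)amino group will do. With the phenyl group of compound 2 retained and nothing else known, the reasonable expectation is a number near that of compound 2, possibly somewhat lower, and the step of a number 12 percentage points lower from compound 2 to compound 3 (beyond the scatter) is expected to stay within or only slightly beyond the scatter.

Compound 3 is therefore estimated at 8% in this assay, within a range from -15% to 30%.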

Compound 3, a percentage reported as inhibition, at one concentration (the size of the read-out at that concentration, not a potency): -23%
Compound 3: the middle estimate sits 31 percentage points above what was measured; the measured number lies below the stated range.
By their numbers in this assay, from the lowest: compound 3; then compound 1; then compound 2.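

Placed on an aromatic carbon next to the ring nitrogen, the (2-methoxyethyl)amino group turns out to matter in this assay: putting hydrogen in its place gives a number 43 percentage points lower from compound 2 to compound 3 (beyond the scatter), a large step, whereas the earlier step, at another place on the core, was modest. Compound 3 keeps the phenyl group and still gives -23% in this assay, so in this pair the phenyl group alone does not preserve the number reached by compound 2, and the result at this position depends on what sits on that carbon. Nothing measured here explains the size of this drop.

The compounds shown leave open which part of the (2-methoxyethyl)amino group counts: a plain amine or a methylamino group on this carbon would separate the attached nitrogen from the rest of the chain, while a 2-hydroxyethylamino group or a longer chain would probe its far end. They also leave open whether removing the side chain would have a similar effect with methyl in place of phenyl on the core.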